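Swapping sec-butyl for isobutyl on the carbamate oxygen

The source may hold more compounds than are shown below. What is called first, only, known or untested is meant among the compounds shown, and "the series" means these compounds.

Among the measured compounds shown here, compound 2 `CCC(C)OC(=O)NS(=O)(=O)c1sc(CC(C)C)cc1-c1cccc(Cn2ccnc2)c1` gives 440 nM in an assay on HEK293 cells for displacement of a labelled ligand from Type-2 angiotensin II receptor (Homo sapiens), read by scintillation counting, with a stated time of 240 min (a lower number here means a stronger inhibitor, a higher number a weaker inhibitor), which is the higher of the two numbers measured so far, though its only neighbour, compound 1 `COC(=O)NS(=O)(=O)c1sc(CC(C)C)cc1-c1cccc(Cn2ccnc2)c1`, gives 400 nM in this assay, and the gap between them is within the scatter. For the measured compounds named here, the single measured step, a 1.1-fold higher number from compound 1 to compound 2 (0.04 log units; within the scatter), replaced methyl with sec-butyl on the oxygen next to the carbonyl group and left the number essentially where it was.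

Compound 3 `CC(C)COC(=O)NS(=O)(=O)c1sc(CC(C)C)cc1-c1cccc(Cn2ccnc2)c1` has not yet been measured. It differs from compound 2 only in that (isobutyl in place of sec-butyl on an oxygen next to a carbonyl group), so the same four carbons are simply joined in a different branching pattern. Going by the values given here, the one step on record at this same position, from compound 1 to compound 2, was within the scatter even though it changed the size of the group considerably; a rearrangement of an equally sized group is therefore expected to change little. The expected step is a 1.0-fold lower number from compound 2 to compound 3 (0.02 log units; within the scatter), with no change beyond the scatter. Compound 3 is estimated at 420 nM in this assay, within a range from 200 nM to 900 nM.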

Compound 3, inhibition constant: 130 nM
Estimate against measurement, compound 3: 3.2-fold (0.51 log units) above; measured number below the stated range.
By their numbers in this assay, from the lowest: compound 3; then compounds 1 and 2 (each within the scatter of the next).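

In this assay, the position on the oxygen next to a carbonyl group responds to how a chain is joined and not only to which atoms it holds: sec-butyl and isobutyl contain the same atoms, yet exchanging them gives a 3.4-fold lower number from compound 2 to compound 3 (0.53 log units; beyond the scatter) and moves the number beyond the scatter. A larger group does not by itself lower the number here, since the isobutyl compound shows a 3.1-fold lower number from compound 1 to compound 3 (0.49 log units; beyond the scatter) while sec-butyl in place of methyl gave only a 1.1-fold higher number from compound 1 to compound 2 (0.04 log units; within the scatter) and so goes against any simple link between size and a lower number. Among these three compounds, isobutyl alone stands apart, and compound 3 is the strongest inhibitor, with its steps to both others printed as beyond the scatter.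

No measurement here bears on why this arrangement of atoms matters. As far as these compounds go, it also remains open whether a longer chain such as n-butyl, or a ring-bearing group such as benzyl, on this same oxygen would follow isobutyl or fall back with methyl and sec-butyl.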